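Side-chain change on the shared core: compound 2 to compound 4

The compounds below may be only part of what the source reports. "The series", "measured", "known", "first", "only" and "open" are said of these compounds alone.

Three analogues of the shared core have numbers in a functional assay on the whole organism (Tail, strain ICR) with Mus musculus as the target, in the tail flick test, with a stated time of 60 min, at a dose of 25 umol/kg by the oral route; a lower number here means a weaker effect, a higher number a stronger effect of the compound at the dose given. Compound 1 `O=C(CN(c1ncnc2c1ncn2C1CCCCO1)C1CC1)N[C@@H](CO)C(=O)OCc1ccccc1` gives 46.7%, and compound 3 `C[C@H](NC(=O)CN(c1nc(Cl)nc2[nH]cnc12)C1CC1)C(=O)O` gives 44.6%. Compound 2 `O=C(CN(c1nc(Cl)nc2[nH]cnc12)C1CC1)N[C@@H](CC(=O)OCc1ccccc1)C(=O)OCc1ccccc1` gives 22.4%, the lowest of the three; compound 3 stands beyond the scatter above it, and compound 1 further still. Compound 4 `CC(C)C[C@H](NC(=O)CN(c1nc(Cl)nc2[nH]cnc12)C1CC1)C(=O)OCc1ccccc1` differs from compound 2 in one place: isopropyl in place of benzyloxycarbonyl on a saturated chain carbon, two bonds along the chain from an amide-type nitrogen and a carbonyl carbon. For the measured compounds named here, no pair of measured compounds traces this change, so the direction rests only on compound 1 and compound 3 both sitting beyond the scatter above compound 2 with other side chains. A rise beyond the scatter is expected, of roughly the size seen there; the estimated step is a number 17.6 percentage points higher from compound 2 to compound 4 (beyond the scatter). Compound 4 is expected near 40%, in the range 22% to 58%.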

Compound 4, a percentage reported as activity, at one dose (the size of the read-out at that dose, not a potency): 27.3%
For compound 4 the middle estimate is 12.7 percentage points above the measured one; the measured number falls inside the stated range.
By their numbers in this assay, from the lowest: compounds 2 and 4 (each within the scatter of the next); then compounds 3 and 1 (each within the scatter of the next).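

In this assay, isopropyl in place of benzyloxycarbonyl on this saturated chain carbon gives a number 4.9 percentage points higher from compound 2 to compound 4 (within the scatter). At this position, then, the read-out at the dose given does not separate the two side chains, even though the change removes the six-membered aromatic ring and both hydrogen-bond acceptors of the group that leaves. No measurement available here bears on why this is so.

Still open, on these data alone, is whether an amine at the end of a longer chain on this carbon would give a step beyond the scatter.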